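This account rests on a few compounds, and the source may have more. Where it says the series, first, only, none or still open, it means among the compounds named here.

Working notes on the series

The read-out throughout is an ADME assay on liver for metabolic stability, with Liver microsome (Homo sapiens) as the target, using microsomes; on this read-out higher numbers stand for fast clearance and lower numbers for slow clearance. Compound 1 `O=C(NC[C@@H]1CCCO1)c1cn(Cc2ccc(-n3cccn3)cc2)c2cccnc12` gives 133 mL/min/kg, the highest of the two numbers recorded so far. The nearest number belongs to compound 3 `O=C(N[C@H]1CCCC[C@@H]1O)c1cn(Cc2ccc(-n3cccn3)cc2)c2ccccc12`, which in this assay gives 42 mL/min/kg, a gap that lies beyond the usual scatter of the measurement. Compound 2 `Cc1ccc2c(n1)c(C(=O)N[C@H]1CCOC[C@@H]1O)cn2Cc1ccc(-c2ccn(C)n2)cc1`, which carries 3-hydroxyoxan-4-yl on its amide nitrogen, returns in this assay only a limit of < 8 mL/min/kg, not a number (the limit of < 8 mL/min/kg in this assay, at which 1 of the 3 values shown sits).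

Compound 4 `O=C(N[C@H]1CCOC[C@@H]1O)c1cn(Cc2ccc(-n3cccn3)cc2)c2cccnc12` is not yet measured. It differs from compound 1 in one place: 3-hydroxyoxan-4-yl in place of (oxolan-2-yl)methyl on an amide-type nitrogen. The remainder of compound 1 is kept, including the same core and the same substituent on the ring nitrogen.

Both companions that carry a hydroxyl-bearing ring on the amide nitrogen, compound 2 and compound 3, sit well under compound 1, so for this change a fall in clearance beyond the scatter is expected, the step from compound 1 to compound 4 being estimated at a 4.4-fold lower number from compound 1 to compound 4 (0.65 log units; beyond the scatter). Compound 4 is accordingly expected to give 30 mL/min/kg, with a likely range from 10 mL/min/kg to 80 mL/min/kg; a reading at the limit of the assay cannot be excluded.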

Compound 4, clearance: < 8 mL/min/kg
Compound 4: only a limit was reported; the forecaster's own chance of this, stated with the estimate: 15%; middle value at least 3.7-fold (0.57 log units) from the limit.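

Read on an otherwise unchanged compound, the exchange of (oxolan-2-yl)methyl for 3-hydroxyoxan-4-yl on the amide-type nitrogen gives in this assay an at least 16-fold lower number from compound 1 to compound 4 (1.22 log units; beyond the scatter), so this single position can by itself carry a large change in clearance while the shared core and the substituent on the ring nitrogen stay as they are. Compound 4 returns < 8 mL/min/kg, which is a limit of the assay and not a number. The step is therefore a floor, and the full size of the change at this position cannot be read from it: the limit of < 8 mL/min/kg in this assay, at which 2 of the 4 values shown sit.

The change replaces the ring, adds the hydroxyl and alters the link to the amide-type nitrogen all at once, so the compounds shown cannot assign the step to any one of these features. Open as well is how clearance would read with plain oxan-4-yl, which lacks the hydroxyl, or with an amine or a carboxylic acid in place of that hydroxyl on the same ring.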